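This account rests on a few compounds, and the source may have more. Where it says the series, first, only, none or still open, it means among the compounds named here.

Of the compounds shown here, three that share one core have been tested in a functional assay on KG-1 cells (Homo sapiens) for antiproliferative activity; a lower number here means that less compound is needed, a higher number that more compound is needed for the effect. Compound 1 `NC(=O)c1cc(Cl)c2c(Cl)c(C#CCCO)n([C@H]3CCCNC3)c2n1` gives 56 nM. Compound 2 `NC(=O)c1cc(Cl)c2c(Cl)c(C#CC3CCOCC3)n([C@H]3CCCNC3)c2n1` gives 69 nM. Compound 3 `CC(C)(C#N)CC#Cc1c(Cl)c2c(Cl)cc(C(N)=O)nc2n1[C@H]1CCCNC1` gives 113 nM, which is the highest of the three numbers, though its steps to the other two are small: a 2.0-fold higher number from compound 1 to compound 3 (0.30 log units; within the scatter) and a 1.6-fold higher number from compound 2 to compound 3 (0.21 log units; within the scatter). Across these three the numbers therefore cannot be told apart.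

Compound 4 `CC1(CC#Cc2c(Cl)c3c(Cl)cc(C(N)=O)nc3n2[C@H]2CCCNC2)COC1` has not yet been measured. It differs from compound 3 in one place: 3-methyloxetan-3-yl in place of 1-cyano-1-methylethyl on a saturated chain carbon bound to a triple-bonded carbon. For the measured compounds named here, two measured steps bear on this change, as both also alter the group that hangs on the triple bond of the shared core. The step from a hydroxymethyl group to the 1-cyano-1-methylethyl group, a 2.0-fold higher number from compound 1 to compound 3 (0.30 log units; within the scatter), and the step from an oxan-4-yl group to the 2-cyano-2-methylpropyl group, a 1.6-fold higher number from compound 2 to compound 3 (0.21 log units; within the scatter), each stayed within the scatter. Compound 2 carries a ring with one oxygen, as compound 4 will, and its number was lower than that of compound 3 by a margin inside the scatter.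

The step from compound 3 to compound 4 is therefore expected to be a 1.3-fold lower number from compound 3 to compound 4 (0.10 log units; within the scatter), a change of no clear direction. For compound 4 in this assay the estimate is 90 nM, with a likely range from 40 nM to 220 nM.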

Compound 4, half-maximal effective concentration: 289 nM
Estimate against measurement, compound 4: 3.2-fold (0.51 log units) below; measured number above the stated range.
By their numbers in this assay, from the lowest: compounds 1, 2 and 3 (each within the scatter of the next); then compound 4.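

Swapping 1-cyano-1-methylethyl for 3-methyloxetan-3-yl on a saturated chain carbon bound to a triple-bonded carbon gives the first step in this series that lies beyond the scatter in this assay (a 2.6-fold higher number from compound 3 to compound 4 (0.41 log units; beyond the scatter)), even though the two groups have the same count of heavy atoms and of hydrogen-bond acceptors. The gaps to the other two compounds are wider (a 4.2-fold higher number from compound 2 to compound 4 (0.62 log units; beyond the scatter)) and (a 5.2-fold higher number from compound 1 to compound 4 (0.71 log units; beyond the scatter)), so this position does not tolerate every group: compound 4 stands apart from three compounds whose numbers could not be told apart, and having an oxygen in a ring, as the oxan-4-yl group of compound 2 also does, does not keep the number close to theirs. No measurement shown here explains this rise.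

The compounds shown leave open whether the higher number goes with the four-membered ring, with its oxygen, or with the loss of the nitrile. A cyclobutyl group, which has the four-membered ring without the oxygen, or a plain oxetan-3-yl group without the methyl would help to separate these possibilities.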